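This account rests on a few compounds, and the source may have more. Where it says the series, first, only, none or still open, it means among the compounds named here.

In a functional assay on A549 cells (Homo sapiens) for cytotoxicity, read by sulforhodamine B assay, with a stated time of 48 h (a higher number here means a weaker inhibitor, a lower number a stronger inhibitor), compound 1 `COc1ccc(/C=C/C(=O)c2cccc(-c3ccc(F)cc3)c2)cc1` gives 11200 nM and compound 2 `COc1ccc(/C=C/C(=O)c2ccc(NC(C)=O)c(-c3ccc(F)cc3)c2)cc1OC` gives 7380 nM. Going by the values given here, these two values lie within the usual scatter of each other, so compound 1 does not stand apart on the numbers so far. Compound 3 `COc1ccc(/C=C/C(=O)c2ccc(N)c(-c3ccc(F)cc3)c2)cc1` is compound 1 with one change: amino in place of hydrogen on an aromatic carbon, ortho to a 4-fluorophenyl group (amino in place of hydrogen on an aromatic carbon). Among the compounds with values here, no measured pair shows what such a change does, so only a small shift toward a lower number is expected, perhaps none beyond the scatter. The estimated value for compound 3 is 7000 nM, with an expected range from 2500 nM to 20000 nM.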

Compound 3, half-maximal inhibitory concentration: 4310 nM
For compound 3 the middle estimate is 1.6-fold (0.21 log units) above the measured one, and the stated range covers the measured number.
By their numbers in this assay, from the lowest: compounds 3, 2 and 1 (each within the scatter of the next, the first and the last beyond it).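

In this assay, amino in place of hydrogen on an aromatic carbon, ortho to a 4-fluorophenyl group, gives a 2.6-fold lower number from compound 1 to compound 3 (0.41 log units; beyond the scatter) and so moves the value beyond the scatter, though only modestly. Going by these compounds alone, this is the first single-place change available here, and it shows that this position can respond to a small substitution, with stronger inhibition as the result. Nothing available explains the step. Going by these compounds, whether a hydroxyl or a dimethylamino group on this carbon would give a similar step remains open.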